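Bromo in Place of Nitro: Compound 3 Awaits Measurement

The compounds below may be only part of what the source reports. "The series", "measured", "known", "first", "only" and "open" are said of these compounds alone.

Of the compounds shown here, two built on a shared core have so far been measured in an ADME assay on MRC5 cells (Homo sapiens) for antiproliferative activity, read by MTT assay; on this read-out lower numbers stand for stronger inhibition and higher numbers for weaker inhibition. Compound 1 (`C/C(=N\NC(=O)c1cccc(Br)c1)c1cnccn1`) gives 3120 nM, and compound 2 (`C/C(=N\NC(=O)c1ccc([N+](=O)[O-])cc1)c1cnccn1`) gives 2870 nM. These two values lie within the scatter of each other, so compound 2 cannot be separated from compound 1 on these numbers. Compound 3 (`C/C(=N\NC(=O)c1ccc(Br)cc1)c1cnccn1`) carries bromo in place of nitro on an aromatic carbon, para to a large group (bromo in place of nitro on an aromatic carbon). For the measured compounds named here, no measured pair isolates this change. Compound 1, which also carries bromo, gives 3120 nM, so no shift beyond the scatter is expected in either direction in this assay. The estimated change is a 1.0-fold higher number from compound 2 to compound 3 (0.02 log units; within the scatter), which is expected to stay within the scatter. For compound 3 the estimated value is 3000 nM, with an expected range of 1300 nM to 7000 nM.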

Compound 3, half-maximal inhibitory concentration: 2940 nM
Compound 3: middle estimate off by 1.0-fold (0.01 log units), on the high side; the measured number falls inside the stated range.
By their numbers in this assay, from the lowest: compounds 2, 3 and 1 (each within the scatter of the next).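

In this assay, for the compounds shown here, bromo in place of nitro on an aromatic carbon, para to a large group, gives a 1.0-fold higher number from compound 2 to compound 3 (0.01 log units; within the scatter) and so provides the first comparison of compounds that differ in one place. Compound 2 and compound 3 cannot be told apart, even though a nitro group of 3 heavy atoms with 2 hydrogen-bond acceptors gives way to a single bromine atom with none. No measurement is available here to explain why these two groups read alike.

Only nitro and bromo are shown at this position, so it remains open whether an amine, a carboxylic acid or a longer chain there would also stay within the scatter of compound 2. From the compounds shown here alone, it is equally open whether this exchange would read the same way on a different core.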